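The source may hold more compounds than are shown below. What is called first, only, known or untested is meant among the compounds shown, and "the series" means these compounds.

Of the compounds shown here, three built on one shared core have been measured in an assay (strain Wistar) for inhibition of Amine oxidase [flavin-containing] A (Rattus norvegicus); a lower number here means a stronger inhibitor, a higher number a weaker inhibitor. Compound 1 `NC(=O)[C@@H]1CCCN1Cc1cc(=O)oc2cc(OCc3ccccc3)ccc12` gives 35000 nM. Compound 2 `CC(C(N)=O)c1cc(=O)oc2cc(OCc3ccccc3)ccc12` gives 6260 nM in this assay. Compound 3 `CN(C)C(=O)Cc1cc(=O)oc2cc(OCc3ccccc3)ccc12` gives 23100 nM in this assay, which places it as the second highest of the three numbers: its nearest neighbour is compound 1, at a gap within the scatter, while compound 2 stands furthest from it, at a gap beyond the scatter.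

Compound 4 `CNCc1cc(=O)oc2cc(OCc3ccccc3)ccc12` has not yet been measured. It differs from compound 3 at one place: methylamino in place of dimethylcarbamoyl on a saturated chain carbon bound to an aromatic carbon.

Among the measured compounds shown here, two measured steps bear on this change. The step of a 1.5-fold lower number from compound 1 to compound 3 (0.18 log units; within the scatter) also exchanged one group at the same saturated chain carbon, and it stayed within the scatter. The step of a 3.7-fold higher number from compound 2 to compound 3 (0.57 log units; beyond the scatter) altered the side chain in a different way and moved the number modestly. Neither step involves a methylamino group, so the direction of the new step is uncertain; among these three compounds, changes to the side chain have shifted the number only modestly. For compound 4 the expectation is therefore a step of a 1.5-fold lower number from compound 3 to compound 4 (0.19 log units; within the scatter), with the value estimated at 15000 nM and a range from 3000 nM to 60000 nM.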

Compound 4, half-maximal inhibitory concentration: 15400 nM
For compound 4 the middle estimate is 1.0-fold (0.01 log units) below the measured one; the measured number falls inside the stated range.
By their numbers in this assay, from the lowest: compound 2; then compounds 4, 3 and 1 (each within the scatter of the next, the first and the last beyond it).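

In this assay, the saturated chain carbon bound to an aromatic carbon can now be compared with and without a carbonyl in its group: replacing dimethylcarbamoyl with the smaller methylamino, which also brings a hydrogen-bond donor, gives a 1.5-fold lower number from compound 3 to compound 4 (0.18 log units; within the scatter) and so leaves the number unchanged within the scatter. Two wider comparisons, a 2.3-fold lower number from compound 1 to compound 4 (0.36 log units; beyond the scatter) and a 2.5-fold higher number from compound 2 to compound 4 (0.39 log units; beyond the scatter), are both beyond the scatter but modest, so the amine side chain sits among the amide side chains and does not break away from them in either direction. No measurement shown gives a reason why methylamino and dimethylcarbamoyl read alike here.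

With methylamino as the only amine at this carbon, the loss of the carbonyl, the smaller group and the new hydrogen-bond donor cannot be told apart, and a dimethylamino group would separate the donor from the other two. On these data alone, whether an unsubstituted amine, a carboxylic acid or a longer chain on the nitrogen would move the number any further also remains open.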